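The compounds below may be only part of what the source reports. "The series", "measured", "known", "first", "only" and "open" are said of these compounds alone.

Values in a functional assay on HepG2 cells (Homo sapiens) for antiproliferative activity, read by MTT assay, with a stated time of 72 h (a lower number here means a stronger inhibitor, a higher number a weaker inhibitor), so far:

Compound 1 `O=C(N/N=C/c1ccccc1)Nc1ccc(Oc2ccnc3[nH]ccc23)c(F)c1` gives 640 nM
Compound 2 `O=C(N/N=C/c1ccc(Br)cc1)Nc1ccc(Oc2ccnc3[nH]ccc23)c(F)c1` gives 1000 nM
Compound 3 `N#Cc1ccc(/C=N/NC(=O)Nc2ccc(Oc3ccnc4[nH]ccc34)c(F)c2)cc1` gives 850 nM

Compound 3 (850 nM) lies within the scatter of both other compounds. Compound 4 (`O=C(N/N=C/c1ccc([N+](=O)[O-])cc1)Nc1ccc(Oc2ccnc3[nH]ccc23)c(F)c1`) differs from it in one place, with nitro in place of cyano on an aromatic carbon. Going by the values given here, no compound here carries nitro yet, so the only guide is the other changes on that carbon. Those steps were small, and all stayed within the scatter (a 1.6-fold higher number from compound 1 to compound 2 (0.19 log units; within the scatter); a 1.3-fold higher number from compound 1 to compound 3 (0.12 log units; within the scatter); a 1.2-fold lower number from compound 2 to compound 3 (0.07 log units; within the scatter)). No step beyond the scatter is therefore expected in this assay for this swap. The expected step is equally small (a 1.1-fold lower number from compound 3 to compound 4 (0.03 log units; within the scatter)). For compound 4 the estimate is 800 nM with an expected range from 380 nM to 1700 nM in this measurement.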

Compound 4, half-maximal inhibitory concentration: 3030 nM
Compound 4: middle estimate off by 3.8-fold (0.58 log units), on the low side; measured number outside the range, above it.
By their numbers in this assay, from the lowest: compounds 1, 3 and 2 (each within the scatter of the next); then compound 4.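

Going by these compounds alone, at this aromatic carbon, hydrogen, bromo and cyano had stayed within the scatter of one another, but nitro is the first group to shift the number beyond it in this assay (a 3.6-fold higher number from compound 3 to compound 4 (0.55 log units; beyond the scatter); a 3.0-fold higher number from compound 2 to compound 4 (0.48 log units; beyond the scatter); a 4.7-fold higher number from compound 1 to compound 4 (0.68 log units; beyond the scatter)). All three steps point towards a weaker inhibitor, so this position does not accept every group equally. No measurement here explains why. Still open, on these data alone, is whether an amine or a methoxy group at this carbon would behave like nitro or like the other three groups.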